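The source may report more compounds than this note shows. Statements on the series, on what has been measured and on what is new or still open speak of the compounds shown alone.

Working notes on the series, read in a functional assay on DU-145 cells (Homo sapiens) for inhibition, read by MTT assay, with a stated time of 72 h; on this read-out lower numbers stand for stronger inhibition and higher numbers for weaker inhibition. Compound 1 (`COc1ccccc1OS(=O)(=O)C1CC2OC1C(c1ccc(NC(=O)CCCCCCC(=O)NO)cc1)=C2c1ccc(O)cc1`) gives 44700 nM. Compound 2 (`Cc1ccccc1OS(=O)(=O)C1CC2OC1C(c1ccc(NC(=O)CCCCCCC(=O)O)cc1)=C2c1ccc(O)cc1`) gives only a limit, > 100000 nM, so no true number is available for it. Compound 3 (`O=C(O)CCCCCCC(=O)Nc1ccc(C2=C(c3ccc(O)cc3)C3CC(S(=O)(=O)Oc4ccc(F)cc4)C2O3)cc1`) differs from compound 2 in one place, with 4-fluorophenyl in place of 2-methylphenyl on an oxygen whose other neighbour is the sulfonyl sulfur, that is, (2-methylphenoxy)sulfonyl to (4-fluorophenoxy)sulfonyl (4-fluorophenyl in place of 2-methylphenyl on an oxygen). Within the data shown here, no measured step sizes this exchange, so no shift beyond the usual scatter is expected in this assay, and no direction is favoured. This expectation starts from compound 2, whose limit is > 100000 nM. The expected step that the limit leaves unreadable from compound 2 to compound 3 is therefore small, and another limit reading is the likeliest outcome. For compound 3 the estimate is 130000 nM, with an expected range from 60000 nM to 300000 nM.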

Compound 3, half-maximal inhibitory concentration: > 100000 nM
Compound 3 gave a limit, no number; the forecaster's own chance of this, stated with the estimate: 80%; the middle value lies beyond the limit too.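

Compound 2 and compound 3 both give limits rather than numbers, so the step from 2-methylphenyl to 4-fluorophenyl cannot be read: the limit of > 100000 nM in this assay, at which 2 of the 3 values shown sit.

The compounds shown leave open whether these two groups differ at all on this read-out, and if so, in which direction and by how much.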